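Notes on a pyrazolopyridinone series at G-protein coupled receptor 39

The compounds below may be only part of what the source reports. "The series", "measured", "known", "first", "only" and "open" are said of these compounds alone.

Measured compounds:
compound 1 `CCCCCCCCOC1CC(=O)Nc2c1c(C)nn2-c1ncnc2nc[nH]c12` – 388 nM
compound 2 `Cc1nn(-c2ncnc3nc[nH]c23)c2c1C(C(=O)NCc1ccccc1)CC(=O)N2` – 2930 nM
compound 3 `Cc1nn(-c2ncnc3nc[nH]c23)c2c1C(OCCn1nccc1C)CC(=O)N2` – 1620 nM

All three were read in a functional assay on HEK293 cells for agonist activity at G-protein coupled receptor 39 (Homo sapiens), read by scintillation proximity assay and inositol phosphate accumulation, with a stated time of 75 min; on this read-out higher numbers stand for an effect only at larger amounts of compound and lower numbers for an effect already at smaller amounts. Compound 3 gives 1620 nM, the second highest of the three numbers; compound 2 sits nearest, and the gap a 1.8-fold lower number from compound 2 to compound 3 (0.26 log units; within the scatter) lies within the scatter. Compound 1, with octyloxy on the saturated ring carbon, stands furthest, the step of a 4.2-fold higher number from compound 1 to compound 3 (0.62 log units; beyond the scatter) being beyond the scatter.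

Compound 4 `Cc1nn(-c2ncnc3nc[nH]c23)c2c1C(NC(=O)Cc1cccs1)CC(=O)N2` differs from compound 3 by a group of 9 heavy atoms (6 carbon, 1 nitrogen, 1 oxygen, 1 sulfur; one five-membered aromatic ring with 1 hetero atom) in place of a group of 9 heavy atoms (6 carbon, 2 nitrogen, 1 oxygen; one five-membered aromatic ring with 2 hetero atoms), on a saturated ring carbon. Within the data shown here, two measured steps bear on this. The swap a 1.8-fold lower number from compound 2 to compound 3 (0.26 log units; within the scatter) shows that exchanging one aromatic-bearing group for another on this carbon moved the number within the scatter only, and a 7.6-fold higher number from compound 1 to compound 2 (0.88 log units; beyond the scatter) shows that a group carrying an amide and an aromatic ring gave a higher number than the octyloxy of compound 1. Compound 4 carries both an amide and an aromatic ring on the same carbon, so no step beyond the scatter is expected from compound 3, a 1.4-fold higher number from compound 3 to compound 4 (0.13 log units; within the scatter). The estimate for compound 4 in this assay is 2200 nM, with a range from 700 nM to 7000 nM.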

Compound 4, half-maximal effective concentration: 244 nM
For compound 4 the middle estimate is 9.0-fold (0.96 log units) above the measured one; the whole stated range lies above it.
By their numbers in this assay, from the lowest: compounds 4 and 1 (each within the scatter of the next); then compounds 3 and 2 (each within the scatter of the next).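

On the saturated ring carbon, (((thiophen-2-yl)methyl)carbonyl)amino gives a step beyond the scatter from the group of compound 3 in this assay (a 6.6-fold lower number from compound 3 to compound 4 (0.82 log units; beyond the scatter)), so this position responds to the exchange of one five-membered aromatic group for another. An amide and an aromatic ring together do not fix the number here, as compound 2 and compound 4 both carry them and still differ widely (a 12-fold lower number from compound 2 to compound 4 (1.08 log units; beyond the scatter)), while the octyloxy of compound 1 and the new group cannot be told apart (a 1.6-fold lower number from compound 1 to compound 4 (0.20 log units; within the scatter)). No measurement is at hand that accounts for these steps.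

Compound 2 and compound 4 differ in both the way the amide is attached and the aromatic ring, so neither change can be weighed alone. Open also is how phenylacetylamino, a simple amine or a carboxylic acid on this carbon would read.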